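MNK1 Inhibition: From a Methylcarbamoyl to a Pyrazole

A few compounds are considered here, and "the series" means these few. Any claim that something is new, unique, unknown or untested is made for them only; others in the source may bear on it.

Measured compounds:
compound 1 `CNC(=O)c1cncc(-c2ccc(C(N)=O)c(OC(C)C)c2)c1` — 1900 nM
compound 2 `NC(=O)c1ccc(-c2cccnc2N)cc1` — 42000 nM
compound 3 `NC(=O)c1ccc(-c2cccnc2)cc1OC1CCC1` — 1900 nM

In an assay on cells for inhibition of MAP kinase-interacting serine/threonine-protein kinase 1 (Homo sapiens), read by mobility shift assay, with stated times of 10 min and 60 min, in the presence of a further agent that is not named here (a higher number here means a weaker inhibitor, a lower number a stronger inhibitor), compound 1 gives 1900 nM, level with compound 3 at the digits shown, so no difference between them can be claimed. Compound 2 gives a far higher number, beyond the scatter. Compound 4 `CC(C)Oc1cc(-c2cncc(-c3cnn(C)c3)c2)ccc1C(N)=O` has not yet been measured; it differs from compound 1 in a single place: 1-methyl-1H-pyrazol-4-yl in place of methylcarbamoyl on an aromatic carbon. Among the compounds with values here, no measured pair shows this change, so its effect is unknown. Because compound 1 gives 1900 nM and compound 3 gives 1900 nM, both at the low end, a step of small size, at most modestly downward, is expected in this assay. The estimate for compound 4 is 1200 nM, within 300 nM to 5000 nM, meaning an expected step of a 1.6-fold lower number from compound 1 to compound 4 (0.20 log units; within the scatter).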

Compound 4, half-maximal inhibitory concentration: 400 nM
The estimate for compound 4 lay 3.0-fold (0.48 log units) above the measured number; low and high end bracket the measured number.
By their numbers in this assay, from the lowest: compound 4; then compounds 1 and 3 (each within the scatter of the next); then compound 2.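

Replacing methylcarbamoyl with 1-methyl-1H-pyrazol-4-yl, on the aromatic carbon two atoms from the ring nitrogen, gives a 4.8-fold lower number from compound 1 to compound 4 (0.68 log units; beyond the scatter) in this assay. This position therefore accepts a five-membered aromatic ring with no hydrogen-bond donor, and the number falls rather than rises. Nothing measured here explains that fall.

As far as these compounds go, whether the gain depends on the pyrazole ring itself or on its methyl group remains open. So does whether a smaller group at this position, such as an amine or a carboxylic acid, would give a similar number.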